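Chloro to fluoro on the aryl amine of compound 3

The source may hold more compounds than are shown below. What is called first, only, known or untested is meant among the compounds shown, and "the series" means these compounds.

Measured so far:
compound 1 `Clc1cccc(Nc2cccc3ccccc23)c1`: 17 nM
compound 2 `Clc1cccc(Nc2ncnc3ccsc23)c1`: 50 nM
compound 3 `Clc1cccc(Nc2n[nH]c3ccccc23)c1`: 84 nM

In an assay for inhibition of acyl-CoA (8-3)-desaturase (Homo sapiens) (on this read-out lower numbers stand for stronger inhibition and higher numbers for weaker inhibition), compound 3 gives 84 nM, the highest of the three numbers. Against compound 2, which gives 50 nM, the gap is within the usual scatter of this assay; against compound 1, which gives 17 nM, the gap lies beyond it. All three share the chloro-substituted aryl amine and differ only in the bicyclic core, so nothing here yet shows what the halogen on the aryl ring contributes.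

Compound 4 `Fc1cccc(Nc2n[nH]c3ccccc23)c1` tests exactly that: fluoro in place of chloro on an aromatic carbon. Among the compounds with values here, no pair isolates a halogen swap, so no measured step can be leaned on. The expectation for this kind of one-atom exchange is a step from compound 3 to compound 4 of a 1.8-fold higher number from compound 3 to compound 4 (0.25 log units; within the scatter), that is no change beyond the scatter, with a small loss of inhibition being the more likely direction if one occurs. Compound 4 is accordingly estimated at 150 nM, with a range from 50 nM to 450 nM.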

Compound 4, half-maximal inhibitory concentration: 59 nM
Compound 4: middle estimate off by 2.5-fold (0.41 log units), on the high side; measured number inside the range.
By their numbers in this assay, from the lowest: compound 1; then compounds 2, 4 and 3 (each within the scatter of the next).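

In this assay, within the data shown here, the pair compound 3 and compound 4 is the first to isolate the halogen on the aryl amine, and it gives a 1.4-fold lower number from compound 3 to compound 4 (0.15 log units; within the scatter) for fluoro in place of chloro on an aromatic carbon, meta to a large group. On this shared core, inhibition at this level therefore does not depend on chloro specifically, as the two halogens cannot be told apart at this position. No measured evidence available here accounts for this result.

On these data alone, it remains open whether a hydrogen, methoxy, trifluoromethyl or an amine at this position would give a number beyond the scatter from compound 3. As far as these compounds go, it is also open whether the same swap would stay within the scatter on the core of compound 1 or compound 2.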